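Dropping the Trifluoromethoxy Group from Compound 1

The source may report more compounds than this note shows. Statements on the series, on what has been measured and on what is new or still open speak of the compounds shown alone.

Of the compounds shown here, three built on a shared core have been tested in an assay on membranes from brain for binding affinity to Lysophosphatidylserine lipase ABHD12 (Mus musculus), read by fluorescence, with a stated time of 20 min; on this read-out higher numbers stand for weaker inhibition and lower numbers for stronger inhibition. Compound 1 `FC(F)(F)Oc1ccc(Oc2ccnc(N3CCC(NC(=S)Nc4cccnc4)CC3)c2)cc1` gives 410 nM, the highest of the three numbers and therefore the weakest inhibitor measured so far. Compound 2 `Cc1c(Oc2ccc(OC(F)(F)F)cc2)ccnc1N1CCC(NC(=S)Nc2cccnc2)CC1` gives 26 nM, and the recorded step a 16-fold lower number from compound 1 to compound 2 (1.20 log units; beyond the scatter) shows how much a single added methyl on the core moved the number. For the measured compounds named here, compound 3 `FC(F)(F)Oc1ccc(Oc2ccnc(N3CCC(NC(=S)Nc4cccnc4)CC3)c2Cl)cc1Cl` gives 33 nM, a lower number than compound 1, though it differs from compound 1 in more than one place, so no single step is recorded between them.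

Compound 4 `S=C(Nc1cccnc1)NC1CCN(c2cc(Oc3ccccc3)ccn2)CC1` has not yet been measured. It differs from compound 1 in one place only: hydrogen in place of trifluoromethoxy on an aromatic carbon. Going by the values given here, no measured step touches this part of the molecule; the one recorded step concerns the core instead. With no direct guide, the expectation is that losing the trifluoromethoxy will not strengthen inhibition and may weaken it somewhat, so a step of a 2.9-fold higher number from compound 1 to compound 4 (0.47 log units; beyond the scatter) is expected. Compound 4 is thus estimated at 1200 nM, with a range from 300 nM to 5000 nM.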

Compound 4, half-maximal inhibitory concentration: 1900 nM
Estimate against measurement, compound 4: 1.6-fold (0.20 log units) below, within the range that was stated.
By their numbers in this assay, from the lowest: compounds 2 and 3 (each within the scatter of the next); then compound 1; then compound 4.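

In this assay, for the compounds shown here, the change from 4-(trifluoromethoxy)phenyl to phenyl gives a 4.6-fold higher number from compound 1 to compound 4 (0.67 log units; beyond the scatter) and so is the first step that shows this end of the molecule affects inhibition, with hydrogen a poorer choice than trifluoromethoxy at this carbon, para to a large group. The step is modest, and the trifluoromethoxy group is not essential for a measurable number, since compound 4 still gives 1900 nM in this assay. No measurement here says why removing the group raises the number.

A single replacement cannot show which feature of trifluoromethoxy matters, and a methoxy group or a carboxylic acid at the same carbon would help separate the possibilities. On these data alone, it also remains open whether the methyl that lowered the number on the core of compound 1 would have a similar effect with the plain phenyl of compound 4.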